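The source may hold more compounds than are shown below. What is called first, only, known or untested is meant among the compounds shown, and "the series" means these compounds.

Notes on the series in a physicochemical assay for solubility, read by HPLC, using the shake flask method, measured as kinetic solubility, with a stated time of 2 h, at pH 7.4; on this read-out lower numbers stand for lower solubility and higher numbers for higher solubility. Compound 1 `Cc1cc(NCc2ccccn2)n2nc(C)c(-c3ccc(F)cc3)c2n1` carries a methyl on the five-membered ring of the shared core, a 4-fluorophenyl and a pyridylmethylamine. In this assay compound 1 gives < 5000 nM, which is a limit of the assay and not a number. Compound 2 `Cc1cc(NCc2ccccn2)n2ncc(-c3ccc(F)cc3)c2n1` differs from compound 1 by hydrogen in place of methyl on an aromatic carbon. In this assay compound 2 gives < 5000 nM, again a limit. Compound 3 `Cc1cc(NCc2cccs2)n2nc(C)c(-c3ccccc3)c2n1` carries a thienylmethylamine and an unsubstituted phenyl. In this assay compound 3 gives < 5000 nM, also a limit. The step that the two limits leave unreadable from compound 1 to compound 2 cannot be read because both of its ends sit at the limit of < 5000 nM in this assay, at which 3 of the 3 values shown sit. Within the data shown here, compound 2 therefore stands at the limit together with every value shown, and no measured step in this assay has a readable size.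

Compound 4 `Cc1cc(NCc2ccccn2)n2ncc(-c3ccsc3)c2n1` is compound 2 with thiophen-3-yl in place of 4-fluorophenyl on an aromatic carbon. No measured step bears on this change; the only step shown, methyl to hydrogen, was unreadable. Compound 4 is expected to sit where compound 2 sits. The step that the limit leaves unreadable from compound 2 to compound 4 is expected to be none beyond the scatter. The estimate for compound 4 in this assay is 2000 nM, with a range from 300 nM to 7000 nM, and most likely the result is reported again only as a limit.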

Compound 4, solubility: 9000 nM
Estimate against measurement, compound 4: 4.5-fold (0.65 log units) below, and the stated range ends below it.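

In this assay, among these compounds, compound 4 gives 9000 nM, the only one of the values shown that is a number and not a limit. At this place, on an aromatic carbon of a five-membered aromatic ring with 2 nitrogen, thiophen-3-yl in place of 4-fluorophenyl gives an at least 1.8-fold higher number from compound 2 to compound 4 (0.25 log units; that floor lies within the scatter), so this is the one step shown with a readable floor, though its true size stays unknown and the floor alone does not clear the scatter. The change therefore brings a reading off the limit that holds the rest of the series, and compound 4 now gives a number against which later changes can be read in both directions: the limit of < 5000 nM in this assay, at which 3 of the 4 values shown sit.

The compounds shown leave open whether the reading of compound 4 belongs to thiophen-3-yl in particular or would also follow from another group at this place, such as a morpholine, an amine or a carboxylic acid. They also leave open whether thiophen-3-yl gives a similar reading on the shared core with the methyl of compound 1, or with the thienylmethylamine of compound 3 in place of the pyridylmethylamine.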